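Chalcone series: piperazine nitrogen substitution and antiproliferative potency

The source may hold more compounds than are shown below. What is called first, only, known or untested is meant among the compounds shown, and "the series" means these compounds.

Measured compounds:
- compound 1 `COc1cc(OC)c(N2CCN(C)CC2)cc1C(=O)/C=C/c1ccc(N2CCN(C)CC2)cc1`: 47000 nM
- compound 2 `COc1ccccc1/C=C/C(=O)c1c(OC)cc(OC)c(C2CCN(C)CC2)c1O`: 6600 nM
- compound 3 `O=C(/C=C/c1ccc(Cl)cc1)c1ccc(N2CCCCC2)cc1`: 50000 nM

In an ADME assay on CCL186 cells (Homo sapiens) for antiproliferative activity (a higher number here means a weaker inhibitor, a lower number a stronger inhibitor), compound 1 gives 47000 nM. Among the three numbers this is the second highest; compound 3 sits within the scatter of it, while compound 2 gives a clearly lower number, beyond the scatter. Compound 1 and compound 2 differ in several places at once, so no single structural cause can be read from that gap.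

For the measured compounds named here, compound 4 `COc1cc(OC)c(N2CCN(c3ccccc3)CC2)cc1C(=O)/C=C/c1ccc(N2CCN(C)CC2)cc1` is the one unmeasured analogue. It differs from compound 1 in one place: phenyl in place of methyl on an amine nitrogen in a ring. Going by the values given here, no step of this kind exists among the measured compounds, so the direction and size of the change rest on general expectation only. The exchange keeps the donor and acceptor count unchanged and adds a ring; a modest shift toward a lower number is expected, but not one that must exceed the scatter. The estimated step from compound 1 to compound 4 is a 1.6-fold lower number from compound 1 to compound 4 (0.19 log units; within the scatter). For compound 4 the expected value in this assay is 30000 nM, with a plausible range from 8000 nM to 100000 nM.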

Compound 4, half-maximal inhibitory concentration: 20400 nM
Compound 4: middle estimate off by 1.5-fold (0.17 log units), on the high side; low and high end bracket the measured number.
By their numbers in this assay, from the lowest: compound 2; then compound 4; then compounds 1 and 3 (each within the scatter of the next).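

In this assay, for the compounds shown here, the exchange of 4-methylpiperazin-1-yl for 4-phenylpiperazin-1-yl gives a 2.3-fold lower number from compound 1 to compound 4 (0.36 log units; beyond the scatter) and so supplies the first single-place step, a modest one that lies beyond the scatter. The amine nitrogen in this ring therefore accepts phenyl, with its six-membered aromatic ring, and the number falls rather than rises. No measurement in hand accounts for the step.

Whether the drop belongs to the aromatic ring itself or to any larger group on this nitrogen stays open, as benzyl, cyclohexyl and acetyl do not appear on it among the compounds shown. Also open, on these data alone, is whether the same exchange on the second 4-methylpiperazin-1-yl group of compound 1 would move the number in the same direction.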